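A few compounds are considered here, and "the series" means these few. Any claim that something is new, unique, unknown or untested is made for them only; others in the source may bear on it.

Measured compounds:
- compound 1 `COC(=O)CC1CCN(C[C@H]2CN(c3ccc(-n4cc(-c5ccccn5)cn4)c(F)c3)C(=O)O2)CC1` — 1.78
- compound 2 `O=C(OC[C@H]1CN(c2ccc(-n3cc(-c4ccccn4)cn3)c(F)c2)C(=O)O1)c1ccccc1` — 4.21
- compound 3 `O=C1O[C@@H](Cn2ccnc2)CN1c1ccc(-n2cc(-c3ccccn3)cn2)c(F)c1` — 1.73

In a physicochemical assay for lipophilicity, read by HPLC, measured as octanol-water partition (a higher number here means a more lipophilic compound, a lower number a more polar compound), compound 3 gives the lowest of the three numbers; it sits within the scatter of compound 1 and well apart from compound 2, as the drop a number 2.48 log units lower from compound 2 to compound 3 (beyond the scatter) and the flat step a number 0.05 log units lower from compound 1 to compound 3 (within the scatter) show. The same position on the shared core is varied again in compound 4 `O=C(NC[C@H]1CN(c2ccc(-n3cc(-c4ccccn4)cn3)c(F)c2)C(=O)O1)C(F)F`, not yet measured in this assay. The change is ((difluoromethyl)carbonyl)amino in place of 1H-imidazol-1-yl on a saturated chain carbon bound to a saturated ring carbon.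

Both measured steps concern this position. The step of a number 2.43 log units higher from compound 1 to compound 2 (beyond the scatter) and the step of a number 2.48 log units lower from compound 2 to compound 3 (beyond the scatter) show that the group here can move the number a great deal, while the step of a number 0.05 log units lower from compound 1 to compound 3 (within the scatter) shows two quite different groups can also give the same number. Among the compounds with values here, no measured pair carries an amide, so there is no direct precedent; the entering group is small, carries a donor, and is uncharged, so the step from compound 3 to compound 4 is expected to be modest, slightly upward, and possibly within the scatter: a number 0.27 log units higher from compound 3 to compound 4 (within the scatter). Compound 4 is therefore estimated at 2, in the range 1.5 to 2.6.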

Compound 4, partition coefficient: 1.9
Compound 4: the middle estimate sits 0.10 log units above what was measured; the measured number falls inside the stated range.
By their numbers in this assay, from the lowest: compounds 3, 1 and 4 (each within the scatter of the next); then compound 2.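

In this assay, ((difluoromethyl)carbonyl)amino, a group with no ring and with a hydrogen-bond donor, gives a small step of a number 0.17 log units higher from compound 3 to compound 4 (within the scatter) and likewise a number 0.12 log units higher from compound 1 to compound 4 (within the scatter), so a third, quite different group on this saturated chain carbon falls in the same band as 1H-imidazol-1-yl and 4-((methoxycarbonyl)methyl)piperidin-1-yl. Benzoyloxy remains the only group of the four set apart, with a number 2.31 log units lower from compound 2 to compound 4 (beyond the scatter) as the large step. Nothing at hand explains this grouping.

The compounds shown leave open whether benzoylamino in this place would stay with compound 2 or join the other three, which would separate the ester link from the phenyl ring. Also open, going by these compounds, are where a primary amine or a carboxylic acid would fall here, and whether acetylamino, which has no fluorine, would read like ((difluoromethyl)carbonyl)amino.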